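The source may report more compounds than this note shows. Statements on the series, on what has been measured and on what is new or still open speak of the compounds shown alone.

Working notes on the series.

Going by the values given here, compound 1 `COc1ccc(-c2cc(/C=C/C(=O)c3ccc(N)cc3)[nH]n2)cc1` is the first reference point. In a functional assay on SF-268 cells (Homo sapiens) for cytotoxicity, read by sulforhodamine B assay, with a stated time of 48 h, tested at 0.1 uM (on this read-out higher numbers stand for a weaker effect at the one concentration tested and lower numbers for a stronger effect), compound 1 gives 93%. Compound 2 `COc1cc(-c2cc(/C=C/C(=O)c3ccc(Cl)c(Cl)c3)[nH]n2)cc(OC)c1OC` carries the same core with a different aryl group on the carbonyl carbon and a different substitution pattern on the distal aromatic ring. In this assay compound 2 gives 92%. Among the compounds with values here, the two numbers stand within the usual scatter of each other, so no order between compound 1 and compound 2 can be read from them, and no step between the two measured compounds is established. Both values sit close to full activity at the single concentration used, meaning neither compound shows a marked effect there.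

Compound 3 `COc1cc(-c2cc(/C=C/C(=O)c3ccc(F)c(F)c3)[nH]n2)cc(OC)c1OC` has not yet been measured in this assay. Relative to compound 2 the change is 3,4-difluorophenyl in place of 3,4-dichlorophenyl on a carbonyl carbon. Since both measured compounds sit at the same high level and no step between them is shown, the step from compound 2 to compound 3 is expected to remain within the scatter, as no change at the digits printed from compound 2 to compound 3 (within the scatter). Compound 3 is therefore estimated at 92%, with a range from 78% to 104%.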

Compound 3, a percentage reported as activity, at one concentration (the size of the read-out at that concentration, not a potency): 94%
Compound 3: the middle estimate sits 2 percentage points below what was measured, and the stated range covers the measured number.
By their numbers in this assay, from the lowest: compounds 2, 1 and 3 (each within the scatter of the next).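

In this assay, going by these compounds alone, the exchange of 3,4-dichlorophenyl for 3,4-difluorophenyl on a carbonyl carbon gives a number 2 percentage points higher from compound 2 to compound 3 (within the scatter) and is the first step that can be read between compounds differing in one place. At the one concentration tested, this read-out therefore does not separate the two groups at this position, and the shared core stays at the same high level with either of them. Nothing available bears on why this exchange leaves the read-out where it stands.

From the compounds shown here alone, what a carboxylic acid, a nitrile or a longer chain in place of the 3,4-difluorophenyl on this carbonyl carbon would do in this read-out remains open, so it is not yet known whether any group at this position can move the number beyond the scatter. Within the data shown here, compound 1 differs from the other two compounds in more than one place, so no step to it can be read, and the role of the other parts of the shared structure also stays open.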